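Leaving the sulfonyl group: a step back towards higher solubility?

The compounds below may be only part of what the source reports. "The series", "measured", "known", "first", "only" and "open" are said of these compounds alone.

compound 1 `NCCOc1ccc([C@H]2CC[C@]3(CC2)OOC2(O3)C3CC4CC(C3)CC2C4)cc1` gives > 100 ug/mL, which is a limit of the assay and not a number
compound 2 `c1cc([C@H]2CC[C@]3(CC2)OOC2(O3)C3CC4CC(C3)CC2C4)ccc1OCCOC1CCNCC1` gives 50 ug/mL (a number)
compound 3 `NC1CCN(S(=O)(=O)c2ccc([C@H]3CC[C@]4(CC3)OOC3(O4)C4CC5CC(C4)CC3C5)cc2)CC1` gives 12.5 ug/mL (a number)

All three readings come from a physicochemical assay for solubility, read by nephelometry, measured as kinetic solubility, with a stated time of 30 min (a higher number here means a more soluble compound, a lower number a less soluble compound), and the compounds share one core. Within the data shown here, compound 3 holds the lower of the two true numbers (12.5 ug/mL), and the only other true number, from compound 2, lies clearly higher.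

Compound 4 `CC(C)(CN)Oc1ccc([C@H]2CC[C@]3(CC2)OOC2(O3)C3CC4CC(C3)CC2C4)cc1` is the next to be measured. Relative to compound 3 it carries 1-(aminomethyl)-1-methylethoxy in place of (4-aminopiperidin-1-yl)sulfonyl on an aromatic carbon, so the sulfonyl group goes and an ether-linked amine chain, as in compound 1, comes in.

Among the measured compounds shown here, two measured steps bear on this, an at least 8.0-fold lower number from compound 1 to compound 3 (0.90 log units; beyond the scatter) and a 4.0-fold lower number from compound 2 to compound 3 (0.60 log units; beyond the scatter), and each ends at the sulfonyl compound with a lower number. The step of an at least 2.0-fold lower number from compound 1 to compound 2 (0.30 log units; that floor lies within the scatter) adds little, since its floor lies within the scatter. Removing the sulfonyl group should run those two steps in reverse, so a rise of modest size is expected in this assay. The expected change is a 6.0-fold higher number from compound 3 to compound 4 (0.78 log units; beyond the scatter), upward. For compound 4 the estimate is 75 ug/mL, with an expected range from 25 ug/mL to 100 ug/mL as its limits. The reading could also turn out to be only a limit of the assay.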

Compound 4, solubility: > 100 ug/mL
Compound 4 was reported as a limit (the forecaster's own chance of this, stated with the estimate: 40%); middle value at least 1.3-fold (0.12 log units) away from the limit.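

In this assay, putting 1-(aminomethyl)-1-methylethoxy in place of (4-aminopiperidin-1-yl)sulfonyl on the same aromatic carbon gives an at least 8.0-fold higher number from compound 3 to compound 4 (0.90 log units; beyond the scatter), so the exchange of a sulfonyl link for an ether-linked amine chain is now seen directly and in the upward direction, rather than only through steps that end at the sulfonyl compound. The comparison of the two ether-linked chains, an at least 2.0-fold higher number from compound 2 to compound 4 (0.30 log units; that floor lies within the scatter), is only a floor that lies within the scatter, so it does not set these two compounds apart. The step from compound 1 to compound 4 cannot be read, and what 1-(aminomethyl)-1-methylethyl does compared with 2-aminoethyl stays hidden, because both compounds sit at one limit of the assay: the limit of > 100 ug/mL in this assay, at which 2 of the 4 values shown sit.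

The compounds shown do not separate the sulfonyl group from the piperidine ring attached to it, and a sulfonyl group carrying an open-chain amine would pull those two parts apart. They also leave open how an ether chain ending in a carboxylic acid instead of an amine would read in this assay.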